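A step at the assay limit

The source may hold more compounds than are shown below. What is called first, only, known or untested is meant among the compounds shown, and "the series" means these compounds.

In a functional assay on Jurkat cells (Homo sapiens) for cytotoxicity, with a stated time of 24 h (a lower number here means a stronger inhibitor, a higher number a weaker inhibitor), compound 1 (`Nn1c(SCc2ccc([N+](=O)[O-])cc2)nnc1-c1c[nH]c2ccccc12`) gives > 100000 nM as a limit and not a number. Compound 2 (`COc1cccc(CSc2nnc(-c3c[nH]c4ccccc34)n2N)c1`) likewise gives > 100000 nM as a limit. It thus stands at the limit of > 100000 nM in this assay, at which 2 of the 2 values shown sit, and has no exact value. Compound 3 (`Cc1ccc(CSc2nnc(-c3c[nH]c4ccccc34)n2N)cc1`) carries 4-methylphenyl in place of 3-methoxyphenyl on a saturated chain carbon bound to a sulfur. For the measured compounds named here, with no measured step to go on, the expected a number no higher from compound 2 to compound 3 (the limit leaves the size open) stays within the scatter. Compound 3 is estimated at 100000 nM (expected range 40000 nM to 150000 nM).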

Compound 3, half-maximal inhibitory concentration: > 100000 nM
Compound 3 ended at the assay's limit (the forecaster's own chance of this, stated with the estimate: 80%); the middle value lies on the limit itself.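

For the compounds shown here, no step between compound 1, compound 2 and compound 3 can be read, because each gives a limit and not a number: the limit of > 100000 nM in this assay, at which 3 of the 3 values shown sit. From the compounds shown here alone, whether their different groups change cytotoxicity at all remains open.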